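From Piperidine Ester Amide to Methanesulfonamido-Propyl Amide

The compounds below may be only part of what the source reports. "The series", "measured", "known", "first", "only" and "open" are said of these compounds alone.

Two measured compounds share one core and differ only at a single carbonyl carbon. Compound 1 `CC(C)(C)c1ccc(C(=O)N2CCC3(CC2)C(=O)N(CC(=O)NCCO)CN3c2ccccc2)cc1` gives 1000 nM in an assay on HEK293 cells for displacement of a labelled ligand from NPC1-like intracellular cholesterol transporter 1 (Homo sapiens); a higher number here means a weaker inhibitor, a lower number a stronger inhibitor. Within the data shown here, compound 2 `CCOC(=O)C1CCCN(C(=O)CN2CN(c3ccccc3)C3(CCN(C(=O)c4ccc(C(C)(C)C)cc4)CC3)C2=O)C1` gives 8200 nM in this assay, the higher of the two numbers known so far, with compound 1 as its only neighbour. Among the measured compounds shown here, the one step available, an 8.2-fold higher number from compound 1 to compound 2 (0.91 log units; beyond the scatter), accompanied 3-(ethoxycarbonyl)piperidin-1-yl taking the place of (2-hydroxyethyl)amino on that carbonyl carbon. Compound 3 `CC(C)(C)c1ccc(C(=O)N2CCC3(CC2)C(=O)N(CC(=O)NCCCNS(C)(=O)=O)CN3c2ccccc2)cc1` is not yet measured and differs from compound 2 as follows: (3-(methanesulfonamido)propyl)amino in place of 3-(ethoxycarbonyl)piperidin-1-yl on a carbonyl carbon. The group whose arrival coincided with the rise leaves again, and an amino substituent on the carbonyl carbon returns, as compound 1 has one. That single step bears directly on the change, so a fall of about its size is expected. Compound 3 is therefore estimated at 1500 nM, within 500 nM to 5000 nM. That estimate would mean a 5.5-fold lower number from compound 2 to compound 3 (0.74 log units; beyond the scatter).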

Compound 3, half-maximal inhibitory concentration: 10400 nM
The estimate for compound 3 lay 6.9-fold (0.84 log units) below the measured number; the measured number lies above the stated range.
By their numbers in this assay, from the lowest: compound 1; then compounds 2 and 3 (each within the scatter of the next).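

Returning an amino substituent to the carbonyl carbon did not by itself bring back the lower number in this assay: there is a 1.3-fold higher number from compound 2 to compound 3 (0.10 log units; within the scatter), even though (3-(methanesulfonamido)propyl)amino has no ring and carries hydrogen-bond donors, while 3-(ethoxycarbonyl)piperidin-1-yl has a ring and carries none. Among the two amino compounds, the end of the chain matters, with a 10-fold higher number from compound 1 to compound 3 (1.02 log units; beyond the scatter) as (methanesulfonamido)methyl stands in place of hydroxy on a saturated chain carbon, so an amino substituent at this position does not alone secure the number of compound 1. Nothing available explains either step.

Still open, from the compounds shown here alone, is whether the hydroxy itself is needed, or whether a methoxy group, a primary amine or a carboxylic acid at that chain end would serve as well. A longer chain ending in hydroxy is also untested among the compounds shown.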